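Chlorobenzyl Shift Across a Low-Inhibition Series

The source may hold more compounds than are shown below. What is called first, only, known or untested is meant among the compounds shown, and "the series" means these compounds.

Of the compounds shown here, three built on one shared core have been measured in a functional assay on the whole organism (artery, strain albino) with Rattus norvegicus as the target, with a stated time of 60 min, at a dose of 10 mg/kg by the oral route; on this read-out higher numbers stand for more inhibition at the one dose given (going by the name of the read-out) and lower numbers for less inhibition. Compound 1 `CC1=C(C(=O)Nc2ccc(Br)cc2)C(c2ccc(Cl)cc2Cl)N=C(SCc2ccccc2Cl)N1` gives 11.8%. Compound 2 `CC1=C(C(=O)Nc2ccc(Br)cc2)C(c2ccc(Cl)cc2Cl)N=C(SCc2cccc(Cl)c2)N1` gives 6.2%, and compound 3 `COc1ccc(C2N=C(SCc3ccccc3Cl)NC(C)=C2C(=O)Nc2ccc(Br)cc2)cc1` gives 6.7%. Compound 2 differs from compound 1 by 3-chlorophenyl in place of 2-chlorophenyl on a saturated chain carbon bound to a sulfur, and that change made a step of a number 5.6 percentage points lower from compound 1 to compound 2 (within the scatter). Compound 3 differs from compound 1 by 4-methoxyphenyl in place of 2,4-dichlorophenyl on a saturated ring carbon, a change that made a step of a number 5.1 percentage points lower from compound 1 to compound 3 (within the scatter). All three numbers therefore sit close to one another, and none of the steps between them can be told apart from repeat-to-repeat noise.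

Compound 4 `COc1ccc(C2N=C(SCc3cccc(Cl)c3)NC(C)=C2C(=O)Nc2ccc(Br)cc2)cc1` has not yet been measured in this assay. It differs from compound 3 by 3-chlorophenyl in place of 2-chlorophenyl on a saturated chain carbon bound to a sulfur, the same change that turned compound 1 into compound 2; the place where the change occurs is described in the same words in both pairs, so it counts as the same change on a different core, the two cores differing as told above for compound 1 and compound 3.

Because the first pass of this change gave a number 5.6 percentage points lower from compound 1 to compound 2 (within the scatter), compound 4 is expected to lie near the bottom of the group, with an estimated step of a number 3.7 percentage points lower from compound 3 to compound 4 (within the scatter). Since the earlier step was within the scatter, the expectation for compound 4 is wide: an estimate of 3%, ranging from -8% to 14%, is what the data so far support.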

Compound 4, a percentage reported as inhibition, in the whole organism at one dose (the size of the read-out at that dose, not a potency): 15.4%
Compound 4: the middle estimate sits 12.4 percentage points below what was measured; the whole stated range lies below it.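

In this assay, putting 3-chlorophenyl in place of 2-chlorophenyl on a saturated chain carbon bound to a sulfur gave a number 8.7 percentage points higher from compound 3 to compound 4 (within the scatter), which does not repeat what the same change did on the core of compound 1: the same change on two cores in this assay, a number 5.6 percentage points lower (within the scatter) from compound 1 to compound 2 and a number 8.7 percentage points higher (within the scatter) from compound 3 to compound 4, 14.3 percentage points apart, beyond the scatter of two such steps. The other change in this set of four, 4-methoxyphenyl in place of 2,4-dichlorophenyl on a saturated ring carbon, gave a number 9.2 percentage points higher from compound 2 to compound 4 (within the scatter), and it too fails to carry over unchanged: the same change on two cores in this assay, a number 5.1 percentage points lower (within the scatter) from compound 1 to compound 3 and a number 9.2 percentage points higher (within the scatter) from compound 2 to compound 4, 14.3 percentage points apart, beyond the scatter of two such steps. Together these show that, among these four compounds, the effect of either change cannot be taken as a fixed increment from one core to the other, but the two comparisons rest on the same four numbers and so count as a single observation, and they show neither why the two changes interact nor whether this holds elsewhere in the series.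

The compounds shown leave open whether the same dependence would appear with other groups on the saturated ring carbon, such as an unsubstituted phenyl or a pyridine ring, or with an unsubstituted benzyl or a longer chain on the sulfur. Each number also comes from a single oral dose, so the set says nothing about potency.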